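The source may hold more compounds than are shown below. What is called first, only, known or untested is meant among the compounds shown, and "the series" means these compounds.

Measured so far:
compound 1 `CC(=O)O[C@@H]1C[C@@H](C)[C@](O)(CCc2ccoc2)[C@@]2(C)CCCC(C)(C)[C@H]12` — < 5 ug/mL
compound 2 `CO[C@H]1C[C@@]2(CC[C@@]3(O2)[C@H](C)CC[C@H]2C(C)(C)[C@@H](OC(C)=O)CC[C@@]23C)[C@H](OC)O1` — < 5 ug/mL

In a functional assay on ZR-75-30 cells (Homo sapiens) for cytotoxicity, read by MTT assay, with a stated time of 72 h (a higher number here means a weaker inhibitor, a lower number a stronger inhibitor), compound 1 gives < 5 ug/mL, which is a limit of the assay and not a number. Compound 2 likewise returns only a limit, < 5 ug/mL. For the measured compounds named here, both values thus sit at the limit of < 5 ug/mL in this assay, at which 2 of the 2 values shown sit, so no measured step exists and compound 1 cannot be ranked against any other compound. Compound 3 `CC(=O)O[C@@H]1C[C@@H](C)[C@](O)(CCC2=CC(=O)OC2)[C@@]2(C)CCCC(C)(C)[C@H]12` has not been measured; it differs from compound 1 by a group of 6 heavy atoms (4 carbon, 2 oxygen; one five-membered non-aromatic ring with 1 hetero atom) in place of a group of 5 heavy atoms (4 carbon, 1 oxygen; one five-membered aromatic ring with 1 hetero atom), on a saturated chain carbon, two bonds along the chain from a saturated ring carbon. Going by the values given here, with no measured step to lean on, the step expected in this assay is a step that the limit leaves unreadable from compound 1 to compound 3, nothing beyond the scatter. Compound 3 is estimated at 3 ug/mL, with a range from 1 ug/mL to 10 ug/mL.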

Compound 3, half-maximal inhibitory concentration: < 5 ug/mL
Compound 3: a limit, no number; the forecaster's own chance of this, stated with the estimate: 60%; the middle value is on the limit's open side.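

For the compounds shown here, compound 1 and compound 3 both return only limits, so no step between them can be read: the limit of < 5 ug/mL in this assay, at which 3 of the 3 values shown sit. As far as these compounds go, the actual potencies of compound 1, compound 2 and compound 3 remain open, as does any effect of replacing the furan-3-yl group.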